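Cyclohexyl replacing propyl on the ring nitrogen of compound 2

A few compounds are considered here, and "the series" means these few. Any claim that something is new, unique, unknown or untested is made for them only; others in the source may bear on it.

Compound 2 `CCCn1nc(C)c2c1NC(=O)CN=C2c1ccccc1Cl` has the lowest of the two numbers measured in a functional assay on the whole organism with Rattus norvegicus as the target; a higher number here means that more compound is needed for the effect, a lower number that less compound is needed; compound 1 `Cn1ncc2c1NC(=O)CN=C2c1ccccc1` gives 250 mg/kg, a gap beyond the usual scatter, while compound 2 gives 63 mg/kg. Compound 3 `CCCCn1nc(C)c2c1NC(=O)CN=C2c1cccc(Cl)c1` reached only a limit of the assay, > 500 mg/kg, as the limit of > 500 mg/kg in this assay, at which 1 of the 3 values shown sits, shows. Compound 4 `Cc1nn(C2CCCCC2)c2c1C(c1ccccc1Cl)=NCC(=O)N2` is not yet measured; it differs from compound 2 by cyclohexyl in place of propyl on an aromatic nitrogen. Going by the values given here, no measured pair shows this change alone, so its effect is uncertain; a moderate rise in dose is expected, giving a step of a 2.0-fold higher number from compound 2 to compound 4 (0.30 log units; within the scatter) that lies beyond the scatter. For compound 4 the expected value in this assay is 125 mg/kg, with a range from 40 mg/kg to 400 mg/kg.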

Compound 4, minimum effective dose: > 500 mg/kg
Compound 4 gave a limit, no number; the forecaster's own chance of this, stated with the estimate: 25%; middle value at least 4.0-fold (0.60 log units) away from the limit.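

In this assay, the group on this aromatic nitrogen clearly matters: cyclohexyl in place of propyl gives an at least 7.9-fold higher number from compound 2 to compound 4 (0.89 log units; beyond the scatter). This is the only pair shown that differs in one place, so the rise can be tied to this change alone, though its full size stays unknown. Compound 4 gives a limit of the assay, not a number: the limit of > 500 mg/kg in this assay, at which 2 of the 4 values shown sit.

On these data alone, what stays open is whether the ring itself or the number of carbons drives the rise. A cyclopropyl ring or a hexyl chain on this nitrogen would separate the two.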